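Arylated C-glycoside ketones against lysosomal alpha-glucosidase

This account rests on a few compounds, and the source may have more. Where it says the series, first, only, none or still open, it means among the compounds named here.

Working notes on three measured members of the series and one still to be measured. Compound 1 `CCOC(=O)C(C(=O)OCC)C(CC(=O)C[C@@H]1O[C@H](CO)[C@@H](O)[C@H](O)[C@H]1O)c1cccnc1` is read in an assay on isolated protein for inhibition of lysosomal alpha-glucosidase (Rattus norvegicus), tested at 100 uM (on this read-out higher numbers stand for more inhibition at the one concentration tested (going by the name of the read-out) and lower numbers for less inhibition), and gives -20%. Compound 2 `O=C(/C=C/c1cccnc1)C[C@@H]1O[C@H](CO)[C@@H](O)[C@H](O)[C@H]1O` gives -35.4% in this assay, and compound 3 `O=C(/C=C/c1ccccc1)C[C@@H]1O[C@H](CO)[C@@H](O[C@@H]2O[C@H](CO)[C@@H](O)[C@H](O)[C@H]2O)[C@H](O)[C@H]1O` gives -24.6%. Among the compounds with values here, every number so far sits at or below zero, so none of the three shows inhibition at the single concentration used. Compound 1 is the highest of the three numbers; its gap to compound 3 is within the usual scatter, while its gap to compound 2 lies beyond the scatter, so compound 1 stands above compound 2 but cannot be separated from compound 3.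

The step considered runs from compound 1 to compound 4 `CCOC(=O)C(C(=O)OCC)C(CC(=O)C[C@@H]1O[C@H](CO)[C@@H](O)[C@H](O)[C@H]1O)c1ccc(Cl)cc1`. The change is 4-chlorophenyl in place of pyridin-3-yl on a saturated chain carbon bound to two saturated chain carbons. Both groups are aromatic six-membered rings on the same saturated chain carbon, and the rest of the molecule is unchanged.

Within the data shown here, no measured pair differs in one place, so no step size can be read from the data. Given that compound 1 gives -20% and the other two members give numbers of the same sign, the step from compound 1 to compound 4 is expected to be a number 2 percentage points higher from compound 1 to compound 4 (within the scatter), with no move beyond the scatter in either direction. For compound 4 in this assay the expected value is -18%, in the range -40% to 5%.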

Compound 4, a percentage reported as inhibition, at one concentration (the size of the read-out at that concentration, not a potency): -10%
Compound 4: the middle estimate sits 8 percentage points below what was measured; measured number inside the range.
By their numbers in this assay, from the lowest: compound 2; then compounds 3, 1 and 4 (each within the scatter of the next, the first and the last beyond it).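

In this assay, within the data shown here, the exchange of pyridin-3-yl for 4-chlorophenyl on a saturated chain carbon bound to two saturated chain carbons gives the only step that can be read, a number 10 percentage points higher from compound 1 to compound 4 (within the scatter), so the two aryl groups cannot be separated at this position. The exchange removes a ring hetero atom and a hydrogen-bond acceptor and adds a chlorine, yet compound 4 at -10% still shows no inhibition at the single concentration tested. Nothing at hand explains the size of this step.

Still open, from the compounds shown here alone, is whether any group on this saturated chain carbon can bring the number above zero, as a 4-methoxyphenyl, a cyclohexyl or a simple aminomethyl group in place of the aromatic ring might show when set against compound 1 and compound 4. Also open, going by these compounds, is whether the two ethyl ester groups matter to the read-out, which free carboxylic acids in their place, on otherwise unchanged compound 4, would test.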